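A Methoxy Group in Place of Fluoro

The source may report more compounds than this note shows. Statements on the series, on what has been measured and on what is new or still open speak of the compounds shown alone.

In an ADME assay on CCD-1095SK cells (Homo sapiens) for antiproliferative activity, read by crystal violet staining, with a stated time of 96 h (a higher number here means that more compound is needed for the effect, a lower number that less compound is needed), compound 1 `O[C@@H]1CO[C@@H](Oc2ccc3ccccc3c2)C[C@H]1O` gives 19 uM and compound 2 `O[C@H]1[C@H](Oc2ccc3ccccc3c2)OC[C@@H](O)[C@@H]1F` gives 72 uM. Compound 2 therefore has the higher of the two numbers, and its gap to compound 1 lies beyond the usual scatter. These two compounds do not differ in just one place, so no single change has yet been measured that could size the next step.

Compound 3 `CO[C@@H]1[C@@H](O)[C@H](Oc2ccc3ccccc3c2)OC[C@H]1O` has not yet been measured in this assay. It differs from compound 2 by one change: methoxy in place of fluoro on a saturated ring carbon. This places methoxy in place of fluoro on a saturated ring carbon, next to two ring atoms that each bear a hydroxy group. The data so far do not show what this exchange does, so no step beyond the scatter is expected, with only a slight lean towards a lower number. The expected change is a 1.4-fold lower number from compound 2 to compound 3 (0.16 log units; within the scatter). Compound 3 is expected at 50 uM, with an estimated range of 20 uM to 130 uM.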

Compound 3, concentration for half-maximal effect: 17 uM
For compound 3 the middle estimate is 2.9-fold (0.47 log units) above the measured one; measured number outside the range, below it.
By their numbers in this assay, from the lowest: compounds 3 and 1 (each within the scatter of the next); then compound 2.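

Going by these compounds alone, this is the first single change measured at this position, and it shows that the position is not indifferent to what it carries: in this assay the exchange of fluoro for methoxy gives a 4.2-fold lower number from compound 2 to compound 3 (0.63 log units; beyond the scatter) and so lies beyond the scatter, whereas compounds 1 and 2 differ in more than one place and could not size any single change. On this one pair, the lower number goes with methoxy, the larger of the two groups and the only one of them counted with a hydrogen-bond acceptor, though the pair cannot separate these two differences from each other. Nothing measured here accounts for the step, and no evidence bearing on its cause is available.

On these data alone, what remains open is how other groups on this saturated ring carbon would compare, such as a hydroxy group, an amine or a longer ether chain like ethoxy, and whether any of them would carry the number lower still. Within the data shown here, with only one exchange at this position, no trend with the size or kind of group can be drawn, and it is also unknown whether the same exchange would give a similar step on a different core.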